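The compounds below may be only part of what the source reports. "The series", "measured", "known", "first", "only" and "open" are said of these compounds alone.

Measured in a functional assay on HepG2 cells (Homo sapiens) for inhibition, read by MTT assay, with a stated time of 72 h; a higher number here means a weaker inhibitor, a lower number a stronger inhibitor:
- Compound 1 `Cc1cccc(-n2c(-c3coc4cc(C)c(Cl)cc4c3=O)nc(-c3ccccc3)c2-c2ccccc2)c1`: 6250 nM
- Compound 2 `Cc1cc2occ(-c3nc(-c4ccccc4)c(-c4ccccc4)n3-c3ccc(Cl)cc3)c(=O)c2cc1Cl`: 1560 nM
- Compound 3 `Cc1cc2occ(-c3nc(-c4ccccc4)c(-c4ccccc4)n3-c3ccc(Br)cc3)c(=O)c2cc1Cl`: 6250 nM

Compound 3 shares the highest of these three numbers with compound 1, so it sits at the weak end of this small set. Compound 4 `Cc1cc2occ(-c3nc(-c4ccccc4)c(-c4ccccc4)n3-c3cccc(Cl)c3)c(=O)c2cc1Cl` has not yet been measured. It differs from compound 3 at a single place, with 3-chlorophenyl in place of 4-bromophenyl on an aromatic nitrogen.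

All three measured steps concern this same place. Putting 4-chlorophenyl in place of 3-methylphenyl gave a 4.0-fold lower number from compound 1 to compound 2 (0.60 log units; beyond the scatter). Putting 4-bromophenyl in place of 3-methylphenyl gave no change at the digits printed from compound 1 to compound 3 (within the scatter). The closest comparison for the change of halogen is a 4.0-fold higher number from compound 2 to compound 3 (0.60 log units; beyond the scatter), which hints that chloro may give a lower number than bromo. However, that comparison involves 4-chlorophenyl, not 3-chlorophenyl, and no measured compound carries the 3-chlorophenyl group. Only part of that modest step is therefore expected to carry over, so in this assay the expectation is a slight move towards a lower number, without a clear step beyond the scatter. The expected step is a 1.8-fold lower number from compound 3 to compound 4 (0.25 log units; within the scatter). For compound 4 the estimated value is 3500 nM, with an expected range of 1300 nM to 8000 nM.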

Compound 4, half-maximal inhibitory concentration: 25000 nM
Compound 4: the middle estimate sits 7.1-fold (0.85 log units) below what was measured, outside the stated range (above it).
By their numbers in this assay, from the lowest: compound 2; then compounds 1 and 3 (each within the scatter of the next); then compound 4.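

In this assay, shifting the chlorine from 4-chlorophenyl to 3-chlorophenyl gives a 16-fold higher number from compound 2 to compound 4 (1.20 log units; beyond the scatter) and is the biggest move seen at this position, so where the halogen sits on this ring can matter as much as which halogen it is. The earlier hint that chloro gives a lower number than bromo therefore holds only for the pair compound 2 and compound 3, since 3-chlorophenyl in place of 4-bromophenyl gives a 4.0-fold higher number from compound 3 to compound 4 (0.60 log units; beyond the scatter) and chloro in place of methyl on the same kind of ring gives a 4.0-fold higher number from compound 1 to compound 4 (0.60 log units; beyond the scatter) and compound 4 now stands beyond the scatter above all three others. Nothing shown here offers any measurement that would explain these steps.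

Still open, on these data alone, is what 3-bromophenyl or 4-methylphenyl would give, as only chloro has so far been seen at both ring positions, and the bromo and methyl groups each at one. Also open, as far as these compounds go, is how a different kind of group on this ring, such as an amine or a methoxy group, would compare with these halogens and the methyl group.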